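Acetylating the free amine of compound 3

The source may hold more compounds than are shown below. What is called first, only, known or untested is meant among the compounds shown, and "the series" means these compounds.

- Compound 1 (`CN(C)c1nonc1/C(=N/O)Nc1ccc(F)c(Br)c1`) gives > 36.6 mL/min/kg (a limit, not a number)
- Compound 2 (`COCCNc1nonc1/C(=N/O)Nc1ccc(F)c(Br)c1`) gives > 36.6 mL/min/kg (a limit, not a number)
- Compound 3 (`NCCNc1nonc1/C(=N/O)Nc1ccc(F)c(Br)c1`) gives 15 mL/min/kg
- Compound 4 (`CC(=O)NCCNc1nonc1/C(=N/O)Nc1ccc(F)c(Br)c1`) has not yet been measured

In an ADME assay on liver (Rattus norvegicus) for metabolic stability, read by LC-MS, using S9 fraction and NADPH, with a stated time of 30 min, tested at 5 uM, in the presence of a further agent that is not named here (a higher number here means faster removal of the compound, a lower number slower removal), compound 3 at 15 mL/min/kg is the only one of the three measured compounds with a reported number. Compound 4 arises from compound 3 by acetyl in place of hydrogen on an amine nitrogen (acetyl in place of hydrogen on an amine nitrogen, so that 2-aminoethyl becomes 2-acetamidoethyl). Going by the values given here, two measured steps bear on this change. One is an at least 2.4-fold lower number from compound 2 to compound 3 (0.38 log units; beyond the scatter) and the other is an at least 2.4-fold lower number from compound 1 to compound 3 (0.38 log units; beyond the scatter) (each lies beyond the scatter). Both steps lead to the free amino of compound 3, which compound 4 no longer carries, so a partial return upward is expected. The size of that return cannot be read from these steps, and a limit may be reported instead of a number. The expected change is a 1.7-fold higher number from compound 3 to compound 4 (0.24 log units; within the scatter) in this assay overall. For compound 4 the estimate is 26 mL/min/kg with an expected range from 13 mL/min/kg to 37 mL/min/kg as the likely span.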

Compound 4, clearance: 33.3 mL/min/kg
Compound 4: the middle estimate sits 1.3-fold (0.11 log units) below what was measured; measured number inside the range.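

In this assay, acetylating the amine gives a 2.2-fold higher number from compound 3 to compound 4 (0.35 log units; beyond the scatter), so the 2-acetamidoethyl chain keeps its nitrogen yet loses most of the advantage of compound 3, which shows that the lower number depends on the free amino end and not merely on a nitrogen at that place. Against the earlier compounds the comparison gives only floors, an at least 1.0-fold lower number from compound 2 to compound 4 (0.04 log units; that floor lies within the scatter) and an at least 1.0-fold lower number from compound 1 to compound 4 (0.04 log units; that floor lies within the scatter), and each floor lies within the scatter, so compound 4 cannot be told apart from either. Compound 1 and compound 2 are reported only as a limit, not as a number: the limit of > 36.6 mL/min/kg in this assay, at which 2 of the 4 values shown sit.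

From the compounds shown here alone, how far either of them lies from compound 4 therefore remains unknown. Also open, going by these compounds, is whether the lower number survives with a methylamino end group, a carboxylic acid or a longer chain in place of the 2-aminoethyl group.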